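The source may report more compounds than this note shows. Statements on the series, on what has been measured and on what is new or still open speak of the compounds shown alone.

Compound 3 `CCN(C/C=C/C#CC(C)(C)C)Cc1cccc(OCCN(C)S(=O)(=O)c2ccc(Br)s2)c1` belongs to a set of three close relatives built on one shared core. In a functional assay on HepG2 cells for inhibition of squalene monooxygenase (Homo sapiens) (on this read-out lower numbers stand for stronger inhibition and higher numbers for weaker inhibition), compound 3 gives 390 nM. Compound 1 `CCN(C/C=C/C#CC(C)(C)C)Cc1cccc(OCCNS(=O)(=O)c2cccs2)c1` gives 450 nM in this assay, and compound 2 `CCN(C/C=C/C#CC(C)(C)C)Cc1cccc(OCCN(C)S(=O)(=O)c2nccs2)c1` gives 170 nM. Among these three numbers compound 3 holds the second highest; its nearest neighbour is compound 1, with a 1.2-fold lower number from compound 1 to compound 3 (0.06 log units; within the scatter), while the gap to compound 2 is wider, with a 2.3-fold higher number from compound 2 to compound 3 (0.36 log units; beyond the scatter). The step from compound 1 to compound 2 shows a 2.6-fold lower number from compound 1 to compound 2 (0.42 log units; beyond the scatter).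

Compound 4 `CCN(C/C=C/C#CC(C)(C)C)Cc1cccc(OCCCN(C)S(=O)(=O)c2cccs2)c1` is the unmeasured member. From compound 3 the change is a group of 11 heavy atoms (6 carbon, 1 nitrogen, 2 oxygen, 2 sulfur; one five-membered aromatic ring with 1 hetero atom) in place of a group of 11 heavy atoms (5 carbon, 1 nitrogen, 2 oxygen, 2 sulfur, 1 bromine; one five-membered aromatic ring with 1 hetero atom), on a saturated chain carbon, two bonds along the chain from an oxygen on an aromatic ring. This removes the bromine from the ring on the sulfonyl sulfur and lengthens the chain between the aromatic oxygen and the sulfonamide nitrogen by one carbon.

For the measured compounds named here, the only measured step that touches the bromine is a 1.2-fold lower number from compound 1 to compound 3 (0.06 log units; within the scatter), which also brings in the methyl on the nitrogen and stays within the scatter. Going by the values given here, no measured step tests the longer chain. On this basis compound 4 is expected to show a 1.0-fold higher number from compound 3 to compound 4 (0.01 log units; within the scatter), a step not clearly beyond the scatter in either direction. The estimate for compound 4 in this assay is therefore 400 nM, with a range from 150 nM to 1100 nM.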

Compound 4, half-maximal inhibitory concentration: 6400 nM
Estimate against measurement, compound 4: 16-fold (1.20 log units) below; measured number above the stated range.
By their numbers in this assay, from the lowest: compound 2; then compounds 3 and 1 (each within the scatter of the next); then compound 4.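

Placing the (methyl((thiophen-2-yl)sulfonyl)amino)methyl group on a saturated chain carbon, two bonds along the chain from an oxygen on an aromatic ring, gives a large weakening in this assay against all three earlier compounds (a 16-fold higher number from compound 3 to compound 4 (1.22 log units; beyond the scatter)), (a 38-fold higher number from compound 2 to compound 4 (1.58 log units; beyond the scatter)) and (a 14-fold higher number from compound 1 to compound 4 (1.15 log units; beyond the scatter)). The earlier compounds had shown only modest steps or none beyond the scatter on changes to the ring on the sulfonyl sulfur and the methyl on the nitrogen, whereas these new steps are all large, and the longer chain is the one change common to all three, which makes it the leading suspect at this position without proving it. No measurement shown bears on why the number rises so far.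

The compounds shown include no pair that differs in chain length alone, so the share of the longer chain cannot be separated from that of the bromine, the ring or the methyl on the nitrogen. They also leave open how a still longer chain, or an amine or carboxylic acid on the chain, would read out in this assay.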